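The source may report more compounds than this note shows. Statements on the series, on what has been measured and on what is new or still open speak of the compounds shown alone.

Working notes on the series. Compound 1 `COc1ccc2nc(Nc3ccnc(Nc4ccc(S(N)(=O)=O)cc4)n3)sc2c1` is the reference; in a functional assay on MCF7 cells (Homo sapiens) for antiproliferative activity, read by MTT assay, with a stated time of 48 h (a higher number here means a weaker inhibitor, a lower number a stronger inhibitor), compound 1 gives 11000 nM, which is the highest of the two plain numbers recorded, with compound 2 nearest. Compound 2 `NS(=O)(=O)c1ccc(Nc2nccc(Nc3nc4ccc(F)cc4s3)n2)cc1` gives 10900 nM in this assay, and the step of a 1.0-fold lower number from compound 1 to compound 2 (0.00 log units; within the scatter) changes nothing beyond the scatter. Compound 3 `COc1ccc2nc(Nc3ccnc(Nc4ccc(S(C)(=O)=O)cc4)n3)sc2c1` reaches only the limit of the assay, > 50000 nM. The step of an at least 4.5-fold higher number from compound 1 to compound 3 (0.65 log units; beyond the scatter) is the one clear movement measured, and it runs toward weaker inhibition.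

Compound 4 `COc1ccc2nc(Nc3nc(Nc4ccc(S(N)(=O)=O)cc4)ncc3C)sc2c1` differs from compound 1 by methyl in place of hydrogen on an aromatic carbon. For the measured compounds named here, neither measured step touches this site: one alters the substituent on the fused ring, the other the group on the sulfonyl sulfur, so no step bears directly on a methyl entering on the six-membered aromatic ring with 2 nitrogen. With no guide, the expectation for compound 4 is a step of a 1.1-fold higher number from compound 1 to compound 4 (0.04 log units; within the scatter) that stays within the scatter, and compound 4 is estimated at 12000 nM, in the range 4000 nM to 40000 nM.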

Compound 4, half-maximal inhibitory concentration: > 50000 nM
Compound 4 gave a limit, no number; the forecaster's own chance of this, stated with the estimate: 15%; at least 4.1-fold (0.61 log units) between middle value and limit.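

The step of an at least 4.5-fold higher number from compound 1 to compound 4 (0.65 log units; beyond the scatter) shows that the shared core does not tolerate every change on the six-membered aromatic ring with 2 nitrogen: in this assay, one methyl on an aromatic carbon ortho to a large group is enough to go beyond the scatter, toward weaker inhibition. For the compounds shown here, the earlier steps touched only the fused ring and the sulfonyl sulfur, so this is the first reading on this ring, and it shows that this position is not silent. How large the loss is cannot be read, because compound 4 stands at a limit and gives no number: the limit of > 50000 nM in this assay, at which 2 of the 4 values shown sit.

Open, from the compounds shown here alone, is whether the loss belongs to methyl alone or to any group on this carbon, such as a hydroxyl, an amine or an ethyl chain. Also open, going by these compounds, is whether the same methyl would act alike with the fluoro of compound 2 on the fused ring.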